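Ortho substitution on the pendant phenyl of the imidazoline ether series

The source may report more compounds than this note shows. Statements on the series, on what has been measured and on what is new or still open speak of the compounds shown alone.

Three compounds of the series have numbers in an assay on CHO cells for displacement of a labelled ligand from Alpha-2C adrenergic receptor (Homo sapiens); on this read-out higher numbers stand for weaker inhibition and lower numbers for stronger inhibition. Compound 1 `Cc1ccc(-c2ccccc2OC(C)C2=NCCN2)cc1` gives 251 nM. Compound 2 `CC(Oc1ccccc1-c1cccnc1)C1=NCCN1` gives 64.6 nM. Compound 3 `CC(Oc1ccccc1-c1ccccc1O)C1=NCCN1` gives 1620 nM, the highest of the three: the step from compound 1 to compound 3 is a 6.5-fold higher number from compound 1 to compound 3 (0.81 log units; beyond the scatter), and the step from compound 2 to compound 3 is a 25-fold higher number from compound 2 to compound 3 (1.40 log units; beyond the scatter).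

Compound 4 `Cc1ccccc1-c1ccccc1OC(C)C1=NCCN1` has not yet been run in this assay. It differs from compound 3 in one place: methyl in place of hydroxy on an aromatic carbon. The change removes the group that is present only in compound 3. The step that bears on it most directly is a 6.5-fold higher number from compound 1 to compound 3 (0.81 log units; beyond the scatter), where the methylphenyl of compound 1 was replaced by the hydroxyphenyl of compound 3; compound 4 moves back to a methylphenyl, though with the methyl at a different position than in compound 1. A lower number than compound 3 is therefore expected, of roughly the size seen between compound 1 and compound 3, giving an estimated step of a 5.4-fold lower number from compound 3 to compound 4 (0.73 log units; beyond the scatter). Compound 4 is expected to give about 300 nM, with a range of 100 nM to 1000 nM.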

Compound 4, inhibition constant: 234 nM
Beside the measured number, compound 4's estimate is 1.3-fold (0.11 log units) above it, and the stated range covers the measured number.
By their numbers in this assay, from the lowest: compound 2; then compounds 4 and 1 (each within the scatter of the next); then compound 3.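

In this assay, methyl in place of hydroxy gives a 6.9-fold lower number from compound 3 to compound 4 (0.84 log units; beyond the scatter) and brings the number back into the range of the methylphenyl compounds, so the high number of compound 3 goes with the hydroxy itself and not with having any substituent on that carbon. Moving the methyl matters little here: 2-methylphenyl and 4-methylphenyl read alike, with a 1.1-fold lower number from compound 1 to compound 4 (0.03 log units; within the scatter) within the scatter, while pyridin-3-yl keeps its lead, with a 3.6-fold higher number from compound 2 to compound 4 (0.56 log units; beyond the scatter) as the step away from it. No measured evidence bearing on these steps is available.

As far as these compounds go, it remains open whether a methoxy or an amine on the same carbon would read like the hydroxy of compound 3 or like the methyl of compound 4. Also open, from the compounds shown here alone, are how a chlorine or a longer chain in place of the methyl would read, and whether the low number of compound 2 survives a methyl added to its pyridin-3-yl.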